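Chlorinated arylidene thiazolidinones: growth inhibition working notes

This account rests on a few compounds, and the source may have more. Where it says the series, first, only, none or still open, it means among the compounds named here.

Three measured compounds share one core. Compound 1 `O=C1NC(=S)/C(=C/c2ccc(Cl)cc2)S1` gives 41.4% in a functional assay on NCI-H292 cells (Homo sapiens) for cytotoxicity, read by MTT assay, with a stated time of 72 h, tested at 10 ug/mL; on this read-out lower numbers stand for less inhibition of growth and higher numbers for more inhibition of growth at the one concentration tested. Compound 2 `O=C1NC(=S)/C(=C/c2ccccc2Cl)S1` gives 45% in this assay; compound 3 `O=C1NC(=S)/C(=C/c2ccc(Cl)c(Cl)c2)S1` gives 43.3%. The difference between the cores of compound 1 and compound 2 is not broken down here. From compound 1 to compound 3 the change is chloro in place of hydrogen on an aromatic carbon, and the step is a number 1.9 percentage points higher from compound 1 to compound 3 (within the scatter).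

Compound 4 `O=C1NC(=S)/C(=C/c2c(Cl)cccc2Cl)S1` is not yet measured. It differs from compound 2 by chloro in place of hydrogen on an aromatic carbon. This is the same kind of change as that from compound 1 to compound 3, not the same: there the entering chloro sat ortho to a chloro group and meta to a group of 8 heavy atoms, here it sits ortho to the group of 8 heavy atoms and meta to a chloro group.

Beside a number 1.9 percentage points higher from compound 1 to compound 3 (within the scatter), the step from compound 2 to compound 4 in this assay is expected to be a number 1 percentage points higher from compound 2 to compound 4 (within the scatter), because the earlier step of a number 1.9 percentage points higher from compound 1 to compound 3 (within the scatter) stayed within the scatter. Compound 4 is therefore estimated at 46%, expected between 36% and 56%.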

Compound 4, percent growth inhibition at one concentration: 32.8%
The estimate for compound 4 lay 13.2 percentage points above the measured number; measured number outside the range, below it.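

In this assay the same change gives a number 12.2 percentage points lower from compound 2 to compound 4 (beyond the scatter), and it does not carry over with one size from one core to the other: the same change on two cores in this assay, a number 1.9 percentage points higher (within the scatter) from compound 1 to compound 3 and a number 12.2 percentage points lower (beyond the scatter) from compound 2 to compound 4, 14.1 percentage points apart, beyond the scatter of two such steps

This rests on a single pair of steps, which does not separate the effect of the starting core from the place of the entering chloro, ortho to the group of 8 heavy atoms and meta to a chloro group in compound 4. It gives no cause for the gap and no rule for other cores in the series.

Open, from the compounds shown here alone, is whether fluoro, methoxy or an amine in that same place would follow the step to compound 4 or the earlier step.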